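This account rests on a few compounds, and the source may have more. Where it says the series, first, only, none or still open, it means among the compounds named here.

Compound 1 `Cc1cc(C)cc(C(=O)N(CCCCCC(=O)Nc2ccccc2N)CC(=O)NC2CCCCC2)c1` gives 17500 nM
Compound 2 `Cc1cc(C)cc(C(=O)N(CC(=O)NCc2ccccc2)Cc2ccc(C(=O)Nc3cc(-c4ccccc4)ccc3N)cc2)c1` gives 8900 nM
Compound 3 `CN(C)c1ccc(C(=O)N(CCCCCC(=O)Nc2cc(F)ccc2N)CC(=O)NCc2ccccc2)cc1` gives 20200 nM

Among the compounds with values here, these numbers come from a functional assay on CAL-27 cells (Homo sapiens) for cytotoxicity, read by MTT assay, with a stated time of 72 h (a lower number here means a stronger inhibitor, a higher number a weaker inhibitor), and no step between them isolates a single change. In this set, compound 3 at 20200 nM lies within the scatter of compound 1. Compound 2 gives 8900 nM in the same test. The gap between compound 3 and compound 2 lies beyond the scatter, with compound 3 having the higher number.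

Compound 4 `CN(C)c1ccc(C(=O)N(CCCCCC(=O)Nc2ccccc2N)CC(=O)NCc2ccccc2)cc1` has not yet been measured. Its structure departs from compound 3 in one place only. The change is hydrogen in place of fluoro on an aromatic carbon and in words it is hydrogen in place of fluoro on an aromatic carbon, so that 2-amino-5-fluorophenyl becomes 2-aminophenyl.

Within the data shown here, no measured pair shows this change on its own. Compound 1 differs from compound 3 in more than one place, yet compound 1 at 17500 nM stays within the scatter of compound 3. On that slim basis, no step beyond the scatter is expected in this assay and no direction is favoured. The estimated move is a 1.2-fold lower number from compound 3 to compound 4 (0.07 log units; within the scatter) and it is expected to stay within the scatter. For compound 4 the expected value is 17000 nM with an estimated range from 8500 nM to 34000 nM as its bounds.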

Compound 4, half-maximal inhibitory concentration: 16000 nM
Beside the measured number, compound 4's estimate is 1.1-fold (0.03 log units) above it, and the stated range covers the measured number.
By their numbers in this assay, from the lowest: compounds 2, 4, 1 and 3 (each within the scatter of the next, the first and the last beyond it).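

In this assay, within the data shown here, hydrogen in place of fluoro gives a 1.3-fold lower number from compound 3 to compound 4 (0.10 log units; within the scatter) and is the first step in this set to isolate a single change. On this aromatic carbon, para to an amino group, 2-amino-5-fluorophenyl and 2-aminophenyl therefore give numbers that cannot be told apart in this pair, so the fluoro group shows no measurable contribution on this scaffold. No measurement is at hand that could account for this result.

On these data alone, whether a chloro, methoxy or trifluoromethyl group at this position would move the number beyond the scatter remains open, as only fluoro and hydrogen are compared here. As far as these compounds go, it is also open whether hydrogen in place of fluoro would read the same way with a cyclohexyl amide, as in compound 1, or with a shorter or longer chain.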